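A few compounds are considered here, and "the series" means these few. Any claim that something is new, unique, unknown or untested is made for them only; others in the source may bear on it.

Within the data shown here, in a functional assay on HL-60 cells (Homo sapiens) for antiproliferative activity, read by MTT assay, with a stated time of 72 h (on this read-out higher numbers stand for weaker inhibition and lower numbers for stronger inhibition), compound 1 (`CCn1cc(C(=O)O)c(=O)c2cc(F)c(N3CCN(C(=N)NS(=O)(=O)c4cccc(Cl)c4)CC3)cc21`) gives 43 nM and so stands level with compound 2 (`N=C(NS(=O)(=O)c1cccc(Cl)c1)N1CCN(c2cc3c(cc2F)c(=O)c(C(=O)O)cn3C2CC2)CC1`) at 43 nM and compound 3 (`N=C(NS(=O)(=O)c1ccc(C(F)(F)F)cc1)N1CCN(c2cc3c(cc2F)c(=O)c(C(=O)O)cn3C2CC2)CC1`) at 43 nM on the numbers so far. Compound 4 (`CCn1cc(C(=O)O)c(=O)c2cc(F)c(N3CCN(C(=N)NS(=O)(=O)c4ccc(C)cc4)CC3)cc21`) differs from compound 1 in one place, with 4-methylphenyl in place of 3-chlorophenyl on a sulfonyl sulfur. Among the measured compounds shown here, two measured steps bear on this change. The closer one also replaces 3-chlorophenyl on a sulfonyl sulfur, in that case with 4-(trifluoromethyl)phenyl, and its size is small (no change at the digits printed from compound 2 to compound 3 (within the scatter)). The other puts cyclopropyl in place of ethyl on an aromatic nitrogen, away from the group being changed here, and it is equally small (no change at the digits printed from compound 1 to compound 2 (within the scatter)). For the measured compounds named here, no measured compound carries 4-methylphenyl, so this exact replacement remains untested, and three matching values are a thin basis for a forecast. With compound 3 at 43 nM after its replacement, no step beyond the scatter is expected in this assay and no direction can be named. The estimated step is correspondingly small (no change at the digits printed from compound 1 to compound 4 (within the scatter)). Compound 4 is estimated at 43 nM with an expected range from 18 nM to 100 nM around that middle value.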

Compound 4, half-maximal inhibitory concentration: 43 nM
Compound 4: middle estimate and measured number agree at the digits printed; the range from low to high includes it.
By their numbers in this assay, from the lowest: compounds 1, 2, 3 and 4 (each within the scatter of the next).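

In this assay, the replacement on the sulfonyl sulfur now has a second reading: no change at the digits printed from compound 1 to compound 4 (within the scatter). The earlier replacement at this place was read on a compound carrying cyclopropyl on the aromatic nitrogen, whereas this one is read on a compound carrying ethyl there, so the flat result is no longer tied to just one of those two groups. The change also takes out the chlorine, leaving a carbon-only 4-methylphenyl with the same count of heavy atoms, so the chlorine is not needed for compound 4 to give 43 nM, although no measurement here explains why the number holds so steady.

From the compounds shown here alone, what stays open is whether the result would hold with a pyridyl ring, a plain methyl group or a longer alkyl chain on the sulfonyl sulfur, or with an amine on the phenyl ring. Since every step at this place so far lies within the scatter in this assay, the compounds shown do not yet reveal which kind of group on the sulfonyl sulfur, if any, would move the number.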